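This account rests on a few compounds, and the source may have more. Where it says the series, first, only, none or still open, it means among the compounds named here.

Compound 1 `COC(=O)[C@@H]1c2cc(/C=C/C(=O)NCCCCNC(=N)N)ccc2O[C@H]1c1ccc(O)cc1` is the better of the two compounds that have a number in an assay on isolated protein (Salivary gland) for displacement of a labelled ligand from Alpha-1A adrenergic receptor (Rattus norvegicus); on this read-out higher numbers stand for weaker inhibition and lower numbers for stronger inhibition: in this assay compound 1 gives 560000 nM, the lower of the two values. Compound 2 `N=C(N)NCCCCNC(=O)/C=C/c1ccc(O)cc1` lacks the substituted core of compound 1 and keeps only the side chain attached to the hydroxyphenyl ring; in this assay compound 2 gives 57600000 nM, a much higher number, and the gap between compound 1 and compound 2 lies beyond the usual scatter.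

Compound 3 `COC(=O)[C@H]1c2cc(/C=C/C(=O)NCCCCNC(=N)N)ccc2O[C@@H]1c1ccc(O)cc1` has not been measured. Compared with compound 1, the change is the two compounds have the same atoms and bonds; at least one stereo element is drawn with a configuration in one of them and without one in the other: 2 of 4 stereo elements differ; a stereocentre at a saturated ring carbon is drawn R in compound 1 and S in compound 3; a stereocentre at a saturated ring carbon is drawn R in compound 1 and S in compound 3, so compound 3 is the mirror image of compound 1 at the two ring stereocentres, with everything else unchanged.

Among the compounds with values here, no pair of measured compounds differing only at these stereocentres is available, so the size of this step has no precedent here. Since compound 1 itself is a weak binder, the expected step from compound 1 to compound 3 in this assay is a 1.4-fold higher number from compound 1 to compound 3 (0.15 log units; within the scatter), a small move towards a higher number that may well fall within the scatter. Compound 3 is therefore expected to give about 800000 nM in this assay, within a range from 150000 nM to 5000000 nM.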

Compound 3, half-maximal inhibitory concentration: 2160000 nM
Estimate against measurement, compound 3: 2.7-fold (0.43 log units) below; the measured number falls inside the stated range.
By their numbers in this assay, from the lowest: compound 1; then compound 3; then compound 2.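

In this assay, inverting the two stereocentres at saturated ring carbons, with the atoms and bonds left the same, gives a 3.9-fold higher number from compound 1 to compound 3 (0.59 log units; beyond the scatter). This shows that the drawn configuration at these positions moves the number on its own, whereas the earlier comparison of compound 1 with compound 2 involved the loss of the whole substituted core. The step is modest, and the only line of support on record for tying it to this place is the following: the fact that one of compounds 1 and 3 is drawn with a defined configuration and the other without, at the place where they differ

The compounds shown include none with just one of the two ring stereocentres inverted, so the step cannot be assigned to either centre alone, and the values give no information on how these compounds bind. On these data alone, it also remains open whether a step of this size would persist if the methyl ester gave way to a carboxylic acid, or if the guanidine at the end of the side chain gave way to a simple amine.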